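The source may report more compounds than this note shows. Statements on the series, on what has been measured and on what is new or still open speak of the compounds shown alone.

Measured so far:
- compound 1, `COc1ccc2ccc(=O)oc2c1C(/C=C/c1ccc(C(F)(F)F)cc1)=N/NC(N)=O`, gives 96 nM in a functional assay on HepG2 cells (Homo sapiens) for cytotoxicity, read by MTT assay, with a stated time of 72 h; a higher number here means a weaker inhibitor, a lower number a stronger inhibitor
- compound 2, `COc1ccc2ccc(=O)oc2c1C1=NN(C(N)=O)C(c2ccc(SC)cc2)C1`, gives 18 nM in this assay
- compound 3, `COc1ccc2ccc(=O)oc2c1C1=NN(C(C)=O)C(c2cccs2)C1`, gives 75 nM in this assay

Compound 1 stands at the highest of the three numbers. Its gap to compound 3 is within the scatter, so the two cannot be ordered; its gap to compound 2 is beyond the scatter, compound 2 showing the lower number. Compound 2 and compound 3 differ from compound 1 in more than one place, so no single step can be read from them.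

Compound 4, `COc1ccc2ccc(=O)oc2c1C(/C=C/c1ccc(SC)cc1)=N/NC(N)=O`, is not yet measured. Relative to compound 1 the change is methylsulfanyl in place of trifluoromethyl on an aromatic carbon. For the measured compounds named here, no measured pair in this set shows that change alone. Compound 2, which carries the same methylsulfanyl-bearing ring on a different core, gives 18 nM, but the core differs too, so its value cannot be assigned to the ring change. The expectation for the step from compound 1 to compound 4 in this assay is therefore modest: a 1.5-fold lower number from compound 1 to compound 4 (0.17 log units; within the scatter), toward a somewhat lower number but possibly not beyond the scatter. Compound 4 is estimated at 65 nM, with a range from 25 nM to 180 nM.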

Compound 4, half-maximal inhibitory concentration: 99 nM
The estimate for compound 4 lay 1.5-fold (0.18 log units) below the measured number, and the stated range covers the measured number.
By their numbers in this assay, from the lowest: compound 2; then compounds 3, 1 and 4 (each within the scatter of the next).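

In this assay, for the compounds shown here, the change from 4-(trifluoromethyl)phenyl to 4-(methylsulfanyl)phenyl on the core of compound 1 gives a 1.0-fold higher number from compound 1 to compound 4 (0.01 log units; within the scatter), the first step that can be read at a single place. On this core, the two groups cannot be told apart at this position, so the ring change alone produces no shift beyond the scatter. The data in hand offer nothing that accounts for this result.

On these data alone, whether an amine, a carboxylic acid or a longer chain at this position would also leave the number in place remains open. Also open is whether the same ring change would read alike on the core of compound 2, where only the methylsulfanyl-bearing ring is shown.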